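The source may hold more compounds than are shown below. What is called first, only, known or untested is meant among the compounds shown, and "the series" means these compounds.

Measured compounds:
Compound 2, `CC1=C(C(=O)Nc2ccc([N+](=O)[O-])cc2)C(c2ccc(Br)cc2)N=C(SCc2ccccc2)N1`, gives 19.6% in a functional assay on the whole organism (artery, strain albino) with Rattus norvegicus as the target, with a stated time of 180 min, at a dose of 10 mg/kg by the oral route; on this read-out lower numbers stand for less inhibition and higher numbers for more inhibition at the one dose given (going by the name of the read-out).
Compound 1, `CC1=C(C(=O)Nc2ccc(Br)cc2)C(c2ccc(Cl)cc2Cl)N=C(SCc2ccccc2)N1`, gives 13.4% in this assay.

Of the compounds shown here, two on the shared core have been measured so far, and both give modest inhibition. Compound 2 returns the number with the higher face value, but its gap to compound 1 lies within the usual scatter, so the two cannot be separated on these data and their inhibition in this assay counts as level. Among the compounds with values here, no single-point step between measured compounds is available.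

Compound 3, `CC1=C(C(=O)Nc2ccc([N+](=O)[O-])cc2)C(c2ccc(Br)cc2)N=C(SCc2ccc(Cl)cc2)N1`, has not yet been measured. Within the data shown here, its only difference from compound 2 is chloro in place of hydrogen on an aromatic carbon. Because the two measured values, 19.6% for compound 2 and 13.4% for compound 1, sit close together, there is no basis in the data for expecting a move beyond the scatter in either direction.

The step from compound 2 to compound 3 is therefore expected to be about a number 0.4 percentage points higher from compound 2 to compound 3 (within the scatter), that is, no change beyond the scatter. Compound 3 is accordingly estimated to give 20% in this assay, with a plausible range from 5% to 40%.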

Compound 3, a percentage reported as inhibition, in the whole organism at one dose (the size of the read-out at that dose, not a potency): 19.1%
Compound 3: middle estimate off by 0.9 percentage points, on the high side; low and high end bracket the measured number.
By their numbers in this assay, from the lowest: compounds 1, 3 and 2 (each within the scatter of the next).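

In this assay, within the data shown here, the change from benzylsulfanyl to (4-chlorobenzyl)sulfanyl, with chloro in place of hydrogen on an aromatic carbon, para to a large group, gives a number 0.5 percentage points lower from compound 2 to compound 3 (within the scatter), and this is the first step on the shared core that can be read at a single place. Compounds 1 and 2 differ in more than one place and could not speak to any one position, whereas this pair shows that chloro at this position leaves the inhibition at this one oral dose level with that of the parent bearing hydrogen. The data offer no explanation for this flat step.

From the compounds shown here alone, whether another group at this position, such as an amine, a carboxylic acid or a methoxy group, would move the read-out beyond the scatter remains open, as does the effect of a longer chain in place of the benzyl group. Going by these compounds, this is also a single pair, so it remains open whether the same chloro change would read the same way alongside the other substituents of compound 1.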